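Benzylsulfanyl in place of propargylsulfanyl on the shared core

The source may hold more compounds than are shown below. What is called first, only, known or untested is meant among the compounds shown, and "the series" means these compounds.

Of the compounds shown here, three have been measured in a functional assay on ECa-109 cells (Homo sapiens) for antiproliferative activity, read by MTT assay, with a stated time of 72 h; a lower number here means a stronger inhibitor, a higher number a weaker inhibitor. Compound 1 `CCCSc1nc(N/N=C/c2ccccc2Cl)c2nnn(Cc3ccccc3)c2n1` gives 6180 nM in this assay. Compound 3 `C#CCSc1nc(N/N=C(\C)c2ccccc2O)c2nnn(Cc3ccccc3)c2n1` gives 5250 nM in this assay, the lowest of the two numbers reported; its gap to compound 1 is within the scatter, so no order between these two can be stated. For compound 2 `CCCSc1nc(N/N=C(\C)c2ccccc2O)c2nnn(Cc3ccccc3Cl)c2n1` this assay returns only a limit, > 64000 nM, which is the limit of > 64000 nM in this assay, at which 1 of the 3 values shown sits, and not a number.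

Compound 4 `C/C(=N\Nc1nc(SCc2ccccc2)nc2c1nnn2Cc1ccccc1)c1ccccc1O` has not been measured in this assay. It differs from compound 3 in one place: phenyl in place of ethynyl on a saturated chain carbon bound to a sulfur, that is propargyl to benzyl, propargylsulfanyl to benzylsulfanyl. No measured pair in the series isolates this change, so the size of the step rests on the spread of the numbers shown. The step from compound 3 to compound 4 is expected to be small, a 1.3-fold higher number from compound 3 to compound 4 (0.12 log units; within the scatter), not clearly beyond the scatter in either direction. For compound 4 the estimate in this assay is 7000 nM, with a range from 2000 nM to 25000 nM.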

Compound 4, half-maximal inhibitory concentration: 1770 nM
For compound 4 the middle estimate is 4.0-fold (0.60 log units) above the measured one, outside the stated range (below it).
By their numbers in this assay, from the lowest: compound 4; then compounds 3 and 1 (each within the scatter of the next). At a limit, above all of these: compound 2.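

Among these compounds, the change propargylsulfanyl to benzylsulfanyl gives the first single-place comparison, and in this assay it yields a 3.0-fold lower number from compound 3 to compound 4 (0.47 log units; beyond the scatter), a modest step beyond the scatter. At this saturated chain carbon bound to a sulfur, exchanging ethynyl for phenyl, with its six-membered aromatic ring of carbon only, is therefore tolerated and gives a lower number in this one pair. No measurement shown accounts for the step.

One pair on one background cannot show whether the aromatic ring itself matters or whether the step would recur with other groups elsewhere on the shared core. A cyclohexyl ring or a longer chain such as pentyl at this sulfur-bound carbon, or a terminal amine or carboxylic acid, would test how far the trend extends.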